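Swapping Methoxy for Cyanomethyl on the Oxetane Ring

This account rests on a few compounds, and the source may have more. Where it says the series, first, only, none or still open, it means among the compounds named here.

In a functional assay on cells for antagonist activity at Free fatty acid receptor 1 (Homo sapiens), read by TR-FRET and inositol phosphate accumulation, with a stated time of 2 h (on this read-out lower numbers stand for stronger inhibition and higher numbers for weaker inhibition), compound 1 `Fc1ccc(OCc2cc(OCC(F)(F)F)nc(-c3ccccn3)n2)c(F)c1F` gives 7.94 nM, compound 2 `CC1(COc2cc(COc3ccc(F)c(F)c3F)nc(-c3ccccn3)n2)COC1` gives 79.4 nM, and compound 3 `COC1(COc2cc(COc3ccc(F)c(F)c3F)nc(-c3ccccn3)n2)COC1` gives 501 nM, the highest of the three numbers. Enlarging the group at the chain carbon raised the numbers: a 10-fold higher number from compound 1 to compound 2 (1.00 log units; beyond the scatter) and a 63-fold higher number from compound 1 to compound 3 (1.80 log units; beyond the scatter). Compound 4 `N#CCC1(COc2cc(COc3ccc(F)c(F)c3F)nc(-c3ccccn3)n2)COC1` differs from compound 3 by cyanomethyl in place of methoxy on a saturated ring carbon. Among the measured compounds shown here, no measured pair swaps these two groups; the nearest guide is the single-group change at the same ring carbon, a 6.3-fold higher number from compound 2 to compound 3 (0.80 log units; beyond the scatter), which was modest. A step of similar size in either direction, or none beyond the scatter, is therefore expected in this assay. Compound 4 is estimated at 400 nM, with a range from 100 nM to 1600 nM. That estimate means an expected step of a 1.3-fold lower number from compound 3 to compound 4 (0.10 log units; within the scatter), within the usual scatter.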

Compound 4, half-maximal inhibitory concentration in the Free fatty acid receptor 1 assay: 398 nM
For compound 4 the middle estimate is 1.0-fold (0.00 log units) above the measured one; the measured number falls inside the stated range.
By their numbers in the Free fatty acid receptor 1 assay, from the lowest: compound 1; then compound 2; then compounds 4 and 3 (each within the scatter of the next).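

In the Free fatty acid receptor 1 assay, methoxy and cyanomethyl on this oxetane carbon cannot be told apart (a 1.3-fold lower number from compound 3 to compound 4 (0.10 log units; within the scatter)), and in a physicochemical assay for lipophilicity, at pH 7.4 (a lower number here means a more polar compound, a higher number a more lipophilic compound), where compound 3 gives 3.5 and compound 4 gives 3.3, the same holds (a number 0.20 log units lower from compound 3 to compound 4 (within the scatter)). Back in the Free fatty acid receptor 1 assay, adding cyano to the methyl group on that ring carbon still leaves a clear gap (a 5.0-fold higher number from compound 2 to compound 4 (0.70 log units; beyond the scatter)). The whole 3-(cyanomethyl)oxetan-3-yl group in place of trifluoromethyl leaves a much wider one (a 50-fold higher number from compound 1 to compound 4 (1.70 log units; beyond the scatter)).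

Nothing available here explains these numbers. From the compounds shown here alone, whether an amine or a carboxylic acid on the same ring carbon would close the gap to the trifluoromethyl compound remains open.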